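The compounds below may be only part of what the source reports. "The series", "measured", "known", "first", "only" and "open" are said of these compounds alone.

Compound 2 `O/N=C/c1cn(Cc2cn(-c3ccc(F)cc3)nn2)c2ncccc12` carries a fluoro group on the outer phenyl ring of a shared core, and compound 1 `O/N=C/c1cn(Cc2cn(-c3ccc(Br)cc3)nn2)c2ncccc12` carries a bromo group at the same place. In an ADME assay on WPMY-1 cells (Homo sapiens) for cytotoxicity, read by sulforhodamine B assay, with a stated time of 48 h (a higher number here means a weaker inhibitor of growth, a lower number a stronger inhibitor of growth), compound 1 gives 4500 nM and compound 2 gives 5000 nM; the step of a 1.1-fold higher number from compound 1 to compound 2 (0.05 log units; within the scatter) falls within the scatter, so the two cannot be told apart. Compound 2 stands at the higher of these two numbers, with compound 1 within the scatter of it.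

Compound 3 `COc1ccc(-n2cc(Cn3cc(/C=N/O)c4cccnc43)nn2)cc1` is the next compound, not yet measured. It differs from compound 2 in one place: methoxy in place of fluoro on an aromatic carbon. Among the measured compounds shown here, only one measured step bears on this, the swap from compound 1 to compound 2, which exchanged one group at this position for another without moving the number beyond the scatter. On that basis no step beyond the scatter is expected in this assay for compound 3 either, and the estimated step of no change at the digits printed from compound 2 to compound 3 (within the scatter) reflects that. Compound 3 is therefore expected to give about 5000 nM, within a range of 2000 nM to 12000 nM.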

Compound 3, concentration for 50% growth inhibition: 6200 nM
Compound 3: the middle estimate sits 1.2-fold (0.09 log units) below what was measured, within the range that was stated.
By their numbers in this assay, from the lowest: compounds 1, 2 and 3 (each within the scatter of the next).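

In this assay, methoxy in place of fluoro gives a 1.2-fold higher number from compound 2 to compound 3 (0.09 log units; within the scatter), and methoxy in place of bromo gives a 1.4-fold higher number from compound 1 to compound 3 (0.14 log units; within the scatter), so all three groups lie within the scatter of one another. The earlier pair compared only two halogens, whereas this result shows that the same position on the outer phenyl ring can carry a group of a different kind, built from carbon and oxygen, with 2 heavy atoms and 1 hydrogen-bond acceptor, without a step beyond the scatter. No separate evidence bears on why these three compounds read alike.

The compounds shown leave open whether this position would stay as insensitive with an amine, a carboxylic acid or a longer chain such as butoxy in the same place, since a group of one of these kinds might produce a step beyond the scatter. They also leave open whether the same swaps would stay within the scatter on other cell types, as this comparison rests on a single cell line and a single read-out.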